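Chloro in place of methyl: compound 2 to compound 3

A few compounds are considered here, and "the series" means these few. Any claim that something is new, unique, unknown or untested is made for them only; others in the source may bear on it.

In an ADME assay on HepG2 cells (Homo sapiens) for cytotoxicity, read by trypan blue exclusion, with a stated time of 48 h, in the presence of a further agent that is not named here (a lower number here means that less compound is tolerated, a higher number that more compound is tolerated), compound 2 (`COc1ccccc1NC(=O)COc1cc(C)nc2ccc(C)cc12`) gives > 74000 nM, which is a limit and not a number. Compound 1 (`COc1ccccc1NC(=O)COc1cc(C)nc2ccc(C(F)(F)F)cc12`) gives > 128000 nM, also a limit, so compound 2 has no exact value to be ranked against.

Compound 3 (`COc1ccccc1NC(=O)COc1cc(C)nc2ccc(Cl)cc12`) differs from compound 2 as follows: chloro in place of methyl on an aromatic carbon. Among the measured compounds shown here, the only measured step that bears on this position is a step that the two limits leave unreadable from compound 1 to compound 2, with methyl in place of trifluoromethyl at the same carbon. That step gives no size to carry over, so no change beyond the scatter is expected in this assay, and no direction is assigned.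

The expected step is a step that the limit leaves unreadable from compound 2 to compound 3. For compound 3 the estimate is 100000 nM, with an expected range of 40000 nM to 200000 nM.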

Compound 3, half-maximal cytotoxic concentration: 99200 nM
Compound 3: middle estimate off by 1.0-fold (0.00 log units), on the high side, and the stated range covers the measured number.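

Among the compounds shown here, compound 3 gives the first exact number at this position in this assay, 99200 nM, so the position now has a measured reference point. Chloro in place of trifluoromethyl gives an at least 1.2-fold lower number from compound 1 to compound 3 (0.11 log units; that floor lies within the scatter), which shows no change beyond the scatter, although the true size of the step may be larger. Compound 2 has only a limit, and the steps that involve it cannot be read: the limit of > 74000 nM in this assay, at which 1 of the 3 values shown sits.

The order of trifluoromethyl, methyl and chloro at this carbon stays unsettled, since neither compound 1 nor compound 2 has an exact number to set beside that of compound 3. Also open, as far as these compounds go, is how an amine or a carboxylic acid on this carbon would read in this assay, and whether any group here brings the number well down.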